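A few compounds are considered here, and "the series" means these few. Any claim that something is new, unique, unknown or untested is made for them only; others in the source may bear on it.

Three compounds carry the same shared core, and all three have been measured in a functional assay on MGC-803 cells (Homo sapiens) for inhibition, read by MTT assay, with a stated time of 48 h; a higher number here means a weaker inhibitor, a lower number a stronger inhibitor. Compound 1, `COc1cc(N(Cc2ccc(F)cc2)S(=O)(=O)c2ccc(C)cc2)cc(OC)c1OC`, gives 3750 nM in this assay. Compound 2, `COc1cc(N(Cc2ccccc2)S(=O)(=O)c2ccc(C)cc2)cc(OC)c1OC`, gives 3570 nM in this assay. The two differ only in one place: fluoro in place of hydrogen on an aromatic carbon; that change produced a 1.1-fold higher number from compound 2 to compound 1 (0.02 log units; within the scatter), a step that sits within the scatter of repeated measurements.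

Compound 3, `COc1cc(N(Cc2nc3ccccc3[nH]2)S(=O)(=O)c2ccccc2)cc(OC)c1OC`, carries a different core; how the core of compound 3 differs from the core of compound 2 is not broken down here. In this assay compound 3 gives 12400 nM, which stands highest of the three numbers, beyond the scatter from both compound 1 and compound 2.

Compound 4, `COc1cc(N(Cc2nc3ccccc3[nH]2)S(=O)(=O)c2ccc(F)cc2)cc(OC)c1OC`, has not yet been measured. It differs from compound 3 in one place: fluoro in place of hydrogen on an aromatic carbon. This is the same change as the one from compound 2 to compound 1, set on the phenylsulfonyl instead of the benzyl, and it is the only change that occurs twice among these compounds. Because the earlier step of a 1.1-fold higher number from compound 2 to compound 1 (0.02 log units; within the scatter) lay within the scatter, the step from compound 3 to compound 4 is expected to be equally small, and the author estimates a 1.0-fold lower number from compound 3 to compound 4 (0.01 log units; within the scatter) in this assay. Compound 4 is therefore estimated to give 12000 nM in this assay, with an expected range from 6000 nM to 25000 nM.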

Compound 4, half-maximal inhibitory concentration: 5680 nM
For compound 4 the middle estimate is 2.1-fold (0.32 log units) above the measured one; the whole stated range lies above it.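

In this assay, fluoro in place of hydrogen on the phenylsulfonyl gave a 2.2-fold lower number from compound 3 to compound 4 (0.34 log units; beyond the scatter), a modest step toward a stronger inhibitor that lies beyond the scatter, whereas the same exchange on the benzyl gave a 1.1-fold higher number from compound 2 to compound 1 (0.02 log units; within the scatter), which lies within it. Within the data shown here, although only one of the two steps stands clear of the scatter, the two cannot be told apart from each other: the same change on two cores in this assay, a 1.1-fold higher number (0.02 log units; within the scatter) from compound 2 to compound 1 and a 2.2-fold lower number (0.34 log units; beyond the scatter) from compound 3 to compound 4, 2.3-fold (0.36 log units) apart, within the scatter of two such steps This shows no firm difference between the two cores, but it does not show that the change carries over unaltered, since there are only two pairs, the fluoro sits on a different ring in each, and the cores differ as well, so a real gain on one core and none on the other remains possible.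

The compounds shown leave open whether chloro, methoxy or an amine in place of that hydrogen on the phenylsulfonyl would move the number the way fluoro does. They also leave open how the methyl group carried on the sulfonyl-bound ring of compound 1 and compound 2 would act on the core of compound 3.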